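This account rests on a few compounds, and the source may have more. Where it says the series, first, only, none or still open, it means among the compounds named here.

In a functional assay on HCT-116 cells (Homo sapiens) for cytotoxicity, read by MTT assay, with a stated time of 72 h (on this read-out lower numbers stand for stronger inhibition and higher numbers for weaker inhibition), three compounds sharing one core have been tested, and none has given a number. Compound 1 `CC(C)(C)OC(=O)N1CCN(c2c(C(=O)NCc3ccc(F)cc3)nc(Br)c3cccnc23)CC1` gives > 10000 nM, which is a limit of the assay. Compound 2 `CN(C)CCCNc1c(C(=O)NCc2ccc(F)cc2)nc(Br)c2cccnc12` gives > 10000 nM, also a limit. Compound 3 `NCCNc1c(C(=O)NCc2ccc(F)cc2)nc(Br)c2cccnc12` gives > 20000 nM, again a limit. Compound 3 therefore stands with the other two, without a true value: the record shows (the limit of > 10000 nM in this assay, at which 2 of the 3 values shown sit), and (the limit of > 20000 nM in this assay, at which 1 of the 3 values shown sits).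

Compound 4 `O=C(NCc1ccc(F)cc1)c1nc(Br)c2cccnc2c1N1CCNCC1` keeps the core and changes one group, which sits para to a bromo group: piperazin-1-yl in place of (2-aminoethyl)amino on an aromatic carbon. Among the measured compounds shown here, the only measured step on this set is a step that the two limits leave unreadable from compound 2 to compound 3, so it offers no size to carry forward.

The expectation rests on compound 3 at > 20000 nM, a limit, and no step beyond the scatter is expected in this assay. The expected change is an at least 1.3-fold lower number from compound 3 to compound 4 (0.12 log units; that floor lies within the scatter). Compound 4 is estimated at 15000 nM, with an expected range from 4000 nM to 40000 nM, and it may well return only a limit.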

Compound 4, half-maximal inhibitory concentration: > 10000 nM
Compound 4: no number, only a limit (the forecaster's own chance of this, stated with the estimate: 75%); the middle value lies beyond the limit too.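

In this assay compound 4 gives > 10000 nM, which is a limit. Among the compounds shown here, with compound 1, compound 2 and compound 3 also returning only limits, no step to compound 4 can be read. The compounds shown leave open whether any group on the shared core gives a true number in this assay.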